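The compounds below may be only part of what the source reports. "The series", "measured", "known", "first", "only" and "open" are said of these compounds alone.

Of the compounds shown here, two sharing one core have so far been measured in a physicochemical assay for solubility, read by HPLC, with a stated time of 24 h; on this read-out higher numbers stand for higher solubility and lower numbers for lower solubility. Compound 1 `CCC(=O)NC[C@H]1CN(c2ccc(-n3cc(-c4ccccn4)cn3)c(F)c2)C(=O)O1` gives 147000 nM, while compound 2 `O=CNC[C@H]1CN(c2ccc(-n3cc(-c4ccccn4)cn3)c(F)c2)C(=O)O1` gives 217000 nM. The one measured step, a 1.5-fold higher number from compound 1 to compound 2 (0.17 log units; within the scatter), means the two compounds cannot be told apart, so compound 2 stands level with compound 1 on the numbers shown. Compound 3 `CCNC(=O)NC[C@H]1CN(c2ccc(-n3cc(-c4ccccn4)cn3)c(F)c2)C(=O)O1` differs from compound 2 by ethylamino in place of hydrogen on a carbonyl carbon. Among the compounds with values here, since the only step that bears on a change at this carbonyl carbon, a 1.5-fold higher number from compound 1 to compound 2 (0.17 log units; within the scatter), was small, a step of a 1.4-fold lower number from compound 2 to compound 3 (0.13 log units; within the scatter) is expected, with no change beyond the scatter. Compound 3 is therefore estimated at 160000 nM, within a range from 70000 nM to 360000 nM.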

Compound 3, solubility: 222000 nM
Compound 3: the middle estimate sits 1.4-fold (0.14 log units) below what was measured, within the range that was stated.
By their numbers in this assay, from the lowest: compounds 1, 2 and 3 (each within the scatter of the next).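

Putting ethylamino in place of hydrogen on this carbonyl carbon gives a 1.0-fold higher number from compound 2 to compound 3 (0.01 log units; within the scatter) in this assay and putting it in place of ethyl gives a 1.5-fold higher number from compound 1 to compound 3 (0.18 log units; within the scatter) in the same test. Hydrogen, ethyl and ethylamino, which brings 3 heavy atoms and 1 hydrogen-bond donor, therefore cannot be told apart here, a result that now spans three groups rather than two. No supporting data offer an explanation for this. On these data alone, whether a longer chain or a carboxylic acid at this carbonyl carbon would give a step beyond the scatter remains open.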